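A few compounds are considered here, and "the series" means these few. Any claim that something is new, unique, unknown or untested is made for them only; others in the source may bear on it.

Measured so far in a functional assay on cells (Splenocyte, Mus musculus, strain BALB/c) for inhibition, read by scintillation counting and thymidine incorporation, with a stated time of 72 h; on this read-out lower numbers stand for stronger inhibition and higher numbers for weaker inhibition:
compound 1 `COc1ccc(C(=O)N/N=C(C)/C=N/Nc2ccc([N+](=O)[O-])cc2)cc1`, > 12000 nM
compound 2 `CC(/C=N/Nc1ccc([N+](=O)[O-])cc1)=N\NC(=O)c1ccc(Cl)cc1`, 4200 nM
compound 3 `CC(/C=N/Nc1ccc([N+](=O)[O-])cc1)=N\NC(=O)c1ccccc1I`, 2980 nM

The value for compound 1 is a limit of this assay, not a number. Compound 3 gives the lowest number of the two numbers in hand; the nearest is compound 2, and the gap between them, a 1.4-fold lower number from compound 2 to compound 3 (0.15 log units; within the scatter), sits within the scatter, so no order between compound 2 and compound 3 can be claimed. Against compound 1 both halogen compounds stand apart: an at least 2.8-fold lower number from compound 1 to compound 2 (0.45 log units; beyond the scatter) and an at least 4.0-fold lower number from compound 1 to compound 3 (0.60 log units; beyond the scatter), each beyond the scatter, though both rest on the limit (the limit of > 12000 nM in this assay, at which 1 of the 3 values shown sits).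

Compound 4 `CC(/C=N/Nc1ccc([N+](=O)[O-])cc1)=N\NC(=O)c1ccc(N)cc1` is not yet measured. It differs from compound 3 by 4-aminophenyl in place of 2-iodophenyl on a carbonyl carbon. Going by the values given here, the steps that bear on it are those in which the aryl group on the carbonyl carbon changes: the two halogen compounds sit below the methoxy compound, while a swap between the two halogen compounds stays within the scatter. Among the compounds with values here, the entering 4-aminophenyl carries a hydrogen-bond donor and acceptor, as the methoxy compound does an acceptor, and no halogen; the nearest precedent is therefore compound 1 at its limit. A rise in the number is expected, a 3.0-fold higher number from compound 3 to compound 4 (0.48 log units; beyond the scatter), with a real chance that only a limit is returned. Compound 4 is estimated at 9000 nM, between 3000 nM and 30000 nM.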

Compound 4, half-maximal inhibitory concentration: > 12000 nM
Compound 4 ended at the assay's limit; the forecaster's own chance of this, stated with the estimate: 40%; middle value at least 1.3-fold (0.12 log units) from the limit.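

Compound 4 in this assay returns a limit, not a number, and so does compound 1: the limit of > 12000 nM in this assay, at which 2 of the 4 values shown sit.

On the carbonyl carbon, the 4-aminophenyl group stands apart from both halogen compounds, with an at least 4.0-fold higher number from compound 3 to compound 4 (0.60 log units; beyond the scatter) and an at least 2.8-fold higher number from compound 2 to compound 4 (0.45 log units; beyond the scatter), each beyond the scatter and each resting on the limit. Among the four compounds, both halogen-bearing aryl groups now give numbers and both aryl groups without a halogen give limits, with no compound going against this, while the step between compound 1 and compound 4 cannot be read, as it joins two limits.

Going by these compounds, whether the halogen itself is what separates these groups stays open, and a plain phenyl, a 4-methylphenyl or a 2-chlorophenyl on the same carbonyl carbon would bear on that question, the last of these also parting the halogen from its place on the ring. On these data alone, how far compound 1 and compound 4 actually lie from the two halogen compounds also stays open, as the sizes of these steps are bounded on one side only.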